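Aryl swaps on the amide nitrogen of the shared core

A few compounds are considered here, and "the series" means these few. Any claim that something is new, unique, unknown or untested is made for them only; others in the source may bear on it.

Measured in a functional assay on NUGC-3 cells (Homo sapiens) for inhibition, read by sulforhodamine B assay, with a stated time of 48 h; a higher number here means a weaker inhibitor of growth, a lower number a stronger inhibitor of growth:
- compound 1 `COc1ccc(NC(=O)C2c3ccccc3CCN2C(=O)c2ccc(Cl)cc2)cc1` gives 3630 nM
- compound 2 `O=C(Nc1ccccc1C(F)(F)F)C1c2ccccc2CCN1C(=O)c1ccc(Cl)cc1` gives > 10000 nM, which is a limit of this assay and not a number

Compound 2 thus stands only at a limit in this assay, with no number of its own. From compound 1 to compound 2 the step was an at least 2.7-fold higher number from compound 1 to compound 2 (0.44 log units; beyond the scatter), and that step rests on (the limit of > 10000 nM in this assay, at which 1 of the 2 values shown sits). Compound 3 `O=C(Nc1ccc(O)cc1)C1c2ccccc2CCN1C(=O)c1ccc(Cl)cc1` differs from compound 2 by 4-hydroxyphenyl in place of 2-(trifluoromethyl)phenyl on an amide-type nitrogen. Within the data shown here, the only measured step that bears on this change is the one from compound 1 to compound 2, in which 4-methoxyphenyl gave the lower number; the move to 4-hydroxyphenyl undoes part of that change. A step back towards the number of compound 1 is therefore expected, of about an at least 2.2-fold lower number from compound 2 to compound 3 (0.34 log units; beyond the scatter) in this assay. For compound 3 the expected value in this assay is 4500 nM, within 1500 nM to 12000 nM.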

Compound 3, concentration for 50% growth inhibition: > 10000 nM
Compound 3: no number, only a limit; the forecaster's own chance of this, stated with the estimate: 30%; middle value at least 2.2-fold (0.34 log units) from the limit.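

In this assay compound 3 gives > 10000 nM, which is a limit of the assay and not a number. Hydrogen in place of methyl on an oxygen on an aromatic ring gives an at least 2.7-fold higher number from compound 1 to compound 3 (0.44 log units; beyond the scatter), so in this series 4-methoxyphenyl on the amide nitrogen cannot be exchanged for 4-hydroxyphenyl without loss of growth inhibition. The step between compound 2 and compound 3 cannot be read, and the reading of this position rests on one measured number and two limits: the limit of > 10000 nM in this assay, at which 2 of the 3 values shown sit.

Where compound 2 and compound 3 truly lie remains open, so 2-(trifluoromethyl)phenyl and 4-hydroxyphenyl cannot be ranked against each other. Also open, from the compounds shown here alone, is whether a longer chain in place of methyl on that oxygen, or an amine in place of the oxygen itself, would keep or lower the number of compound 1.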